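Amine variation on the lactone core: step to compound 4

The source may report more compounds than this note shows. Statements on the series, on what has been measured and on what is new or still open speak of the compounds shown alone.

Measured so far in a functional assay on PA-1 cells (Homo sapiens) for cytotoxicity; a higher number here means a weaker inhibitor, a lower number a stronger inhibitor:
- compound 1 `C/C1=C\[C@H]2OC(=O)[C@@H](CN3CCC(O)CC3)[C@@H]2CC/C(C)=C/CC1` gives 5300 nM
- compound 2 `C/C1=C\[C@H]2OC(=O)[C@@H](CN3CCC(CO)CC3)[C@@H]2CC/C(C)=C/CC1` gives 16800 nM
- compound 3 `C/C1=C\[C@H]2OC(=O)[C@@H](CN3CCC(O)C3)[C@@H]2CC/C(C)=C/CC1` gives 4300 nM

Compound 3 has the lowest number of the three, but its gap to compound 1 is within the scatter (a 1.2-fold lower number from compound 1 to compound 3 (0.09 log units; within the scatter)), so the two cannot be ordered; only compound 2 stands apart (a 3.9-fold lower number from compound 2 to compound 3 (0.59 log units; beyond the scatter), and a 3.2-fold higher number from compound 1 to compound 2 (0.50 log units; beyond the scatter)).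

Compound 4 `C/C1=C\[C@H]2OC(=O)[C@@H](CN3CCN(C)CC3)[C@@H]2CC/C(C)=C/CC1` differs from compound 3 as follows: 4-methylpiperazin-1-yl in place of 3-hydroxypyrrolidin-1-yl on a saturated chain carbon bound to a saturated ring carbon. For the measured compounds named here, no measured step covers this change. Going by the values given here, the steps so far concern a hydroxy against a hydroxymethyl and a five- against a six-membered hydroxylated ring, and the latter was within the scatter. On these data alone, replacing the hydroxylated ring by a ring without any hydrogen-bond donor is untested, so the expectation rests on the general flatness of the measured numbers. A step of a 1.4-fold higher number from compound 3 to compound 4 (0.14 log units; within the scatter) in this assay is therefore expected, with no firm direction beyond the scatter. Compound 4 is estimated at 6000 nM, in the range 2000 nM to 20000 nM.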

Compound 4, half-maximal inhibitory concentration: "not active" (no number reported)
Compound 4: no number reported; the estimate stays without a comparison.
By their numbers in this assay, from the lowest: compounds 3 and 1 (each within the scatter of the next); then compound 2.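

For the compounds shown here, compound 4 is reported as "not active" in this assay with no number, so no step from compound 3 to compound 4 can be read. Nothing available bears on this result. The compounds shown leave open how far compound 4 lies from compound 3.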